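Trading a Trifluoromethyl for Hydrogen: Compound 2 to Compound 3

A few compounds are considered here, and "the series" means these few. Any claim that something is new, unique, unknown or untested is made for them only; others in the source may bear on it.

Of the compounds shown here, two have been tested in an assay on CHO cells, read by calcium flux; on this read-out lower numbers stand for stronger inhibition and higher numbers for weaker inhibition. Compound 1 `O=C(Nc1ccc(C(F)(F)F)cc1)c1csc(Oc2c(Cl)cccc2Cl)n1` gives 870 nM. Compound 2 `O=C(Nc1ccc(C(F)(F)F)cc1)c1csc(Nc2c(Cl)cccc2C(F)(F)F)n1` reaches only the limit of this assay, > 4000 nM, so its true potency is not known. Compound 3 `O=C(Nc1ccc(C(F)(F)F)cc1)c1csc(Nc2ccccc2Cl)n1` has not yet been measured; it differs from compound 2 in one place: hydrogen in place of trifluoromethyl on an aromatic carbon. For the measured compounds named here, no measured pair shows what this change does in this assay, so its effect cannot be read from the data. The step is nonetheless expected to be an at least 1.3-fold lower number from compound 2 to compound 3 (0.12 log units; that floor lies within the scatter). Compound 3 is estimated at 3000 nM, lying between 700 nM and 12000 nM.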

Compound 3, half-maximal inhibitory concentration: 1750 nM
The estimate for compound 3 lay 1.7-fold (0.23 log units) above the measured number; measured number inside the range.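

In this assay, hydrogen in place of trifluoromethyl on this aromatic carbon gives an at least 2.2-fold lower number from compound 2 to compound 3 (0.35 log units; beyond the scatter) and so offers the first measured sign of what this change does. Its full size cannot be read because compound 2 stands at a limit of the assay: the limit of > 4000 nM in this assay, at which 1 of the 3 values shown sits. The (2-chlorophenyl)amino group in place of 2,6-dichlorophenoxy gives a 2.0-fold higher number from compound 1 to compound 3 (0.30 log units; within the scatter) and so does not separate these two compounds.

Whether hydrogen is the best choice on this carbon stays open, since the compounds shown include no methyl, methoxy or nitrile there.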